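A Nitrophenyl Replaces the Dimethoxyphenyl on the Core

A few compounds are considered here, and "the series" means these few. Any claim that something is new, unique, unknown or untested is made for them only; others in the source may bear on it.

Compound 1 `COc1ccc(C2N=C(SCc3cccc(Cl)c3)NC(C)=C2C(=O)Nc2ccc(F)cc2)cc1OC` and compound 2 `COc1ccc(C2N=C(SCc3ccc(Cl)cc3)NC(C)=C2C(=O)Nc2ccc(F)cc2)cc1OC` share a core and differ only in the chlorobenzyl group. In a functional assay on the whole organism (artery, strain albino) with Rattus norvegicus as the target, with a stated time of 120 min, at a dose of 10 mg/kg by the oral route (on this read-out lower numbers stand for less inhibition and higher numbers for more inhibition at the one dose given (going by the name of the read-out)), compound 1 gives 10.8%, and compound 2 gives 15.5%. Of these two numbers, compound 1 has the smaller, but the step of a number 4.7 percentage points higher from compound 1 to compound 2 (within the scatter) lies within the scatter and so marks no real difference.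

Compound 3 `CC1=C(C(=O)Nc2ccc(F)cc2)C(c2ccc([N+](=O)[O-])cc2)N=C(SCc2cccc(Cl)c2)N1` has not been measured. It differs from compound 1 as 4-nitrophenyl in place of 3,4-dimethoxyphenyl on a saturated ring carbon. Within the data shown here, no measured step touches this position of the core; the single step available concerns a 4-chlorophenyl in place of 3-chlorophenyl on a saturated chain carbon bound to a sulfur, and it stayed within the scatter. Nothing in these data therefore points to a move beyond the scatter in this assay, in either direction. Compound 3 is expected to give 13%, within 3% to 25%, which means an estimated step of a number 2.2 percentage points higher from compound 1 to compound 3 (within the scatter).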

Compound 3, a percentage reported as inhibition, in the whole organism at one dose (the size of the read-out at that dose, not a potency): 9.8%
The estimate for compound 3 lay 3.2 percentage points above the measured number, within the range that was stated.
By their numbers in this assay, from the lowest: compounds 3, 1 and 2 (each within the scatter of the next).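

Among these compounds, the step of a number 1 percentage points lower from compound 1 to compound 3 (within the scatter) is the first reading at this saturated ring carbon, a position that the earlier compounds left untouched. In this assay, 4-nitrophenyl and 3,4-dimethoxyphenyl therefore cannot be told apart at the one oral dose given, even though the two groups carry quite different substituents on their aromatic rings. Nothing in the data explains why these two groups read alike.

The compounds shown carry only a substituted phenyl group at this position, so it remains open how a simple methyl group would read there in its place, or how a phenyl ring bearing an amine or a carboxylic acid would read. Going by these compounds, it is also open whether 4-nitrophenyl would read the same alongside the (4-chlorobenzyl)sulfanyl group of compound 2.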